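The source may report more compounds than this note shows. Statements on the series, on what has been measured and on what is new or still open speak of the compounds shown alone.

Of the compounds shown here, three with a shared core have been measured in a functional assay on LNCaP cells (Homo sapiens) for cytotoxicity, read by MTT assay, with a stated time of 72 h; a lower number here means a stronger inhibitor, a higher number a weaker inhibitor. Compound 1 `CC1=C(/C=C/C(=O)/C=C/c2cccc(C(F)(F)F)c2)C(C)(C)CCC1` gives 2800 nM, compound 2 `CC1=C(/C=C/C(=O)/C=C/c2cccc(C(F)(F)F)c2)C(C)(C)CCC1O` gives 740 nM, and compound 3 `CC1=C(/C=C/C(=O)/C=C/c2cc(C(F)(F)F)ccc2C(F)(F)F)C(C)(C)CCC1O` gives 3200 nM. Compound 2 therefore holds the lowest number of the three, and both other values lie beyond the scatter from it.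

Compound 4 `CC1=C(/C=C/C(=O)/C=C/c2cccc(C(F)(F)F)c2F)C(C)(C)CCC1O` differs from compound 2 by one change: fluoro in place of hydrogen on an aromatic carbon, which is fluoro in place of hydrogen on an aromatic carbon, ortho to a trifluoromethyl group. The hydroxy change, a 3.8-fold lower number from compound 1 to compound 2 (0.58 log units; beyond the scatter), sits on a saturated ring carbon and says little here. The closer precedent is trifluoromethyl in place of hydrogen on an aromatic carbon, a 4.3-fold higher number from compound 2 to compound 3 (0.64 log units; beyond the scatter), a modest rise. Fluoro is a smaller group than trifluoromethyl, and this is only one precedent, so a modest rise in the same direction, somewhat smaller, is expected in this assay.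

The estimated change is a 2.2-fold higher number from compound 2 to compound 4 (0.33 log units; beyond the scatter). For compound 4 the expected value is 1600 nM, with an estimated range from 550 nM to 4000 nM.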

Compound 4, half-maximal inhibitory concentration: 1100 nM
Estimate against measurement, compound 4: 1.5-fold (0.16 log units) above, and the stated range covers the measured number.
By their numbers in this assay, from the lowest: compounds 2 and 4 (each within the scatter of the next); then compounds 1 and 3 (each within the scatter of the next).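

In this assay, fluoro in place of hydrogen on the aromatic carbon ortho to a trifluoromethyl group gives a 1.5-fold higher number from compound 2 to compound 4 (0.17 log units; within the scatter), so this single-atom change leaves no readable difference between the two compounds. Within the data shown here, the only earlier aromatic change was a larger one, a 4.3-fold higher number from compound 2 to compound 3 (0.64 log units; beyond the scatter), and that step lies beyond the usual scatter, so not every added group on this aromatic ring is as quiet as fluoro. Nothing measured here gives a cause for this result.

These compounds leave open whether a bigger group at this same carbon, such as chloro, methoxy or an amine, would also leave the number in place. They also leave open whether fluoro behaves in the same way on the other aromatic carbons of the ring.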